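The compounds below may be only part of what the source reports. "The series", "measured", "known", "first", "only" and "open" are said of these compounds alone.

In a functional assay on HCT-116 cells (Homo sapiens) for antiproliferative activity, read by CCK-8 assay, with a stated time of 72 h, tested at 8 uM (on this read-out higher numbers stand for a stronger effect at the one concentration tested and lower numbers for a weaker effect), the three measured compounds stand as follows: compound 1 `Nc1ccccc1NC(=O)c1ccc(COCNc2nc(Nc3ccccc3)c3ncn(C4CCCC4)c3n2)cc1` gives 76.9%; compound 2 `CCCCn1cnc2c(Nc3cccc(Cl)c3)nc(NCOCc3ccc(C(=O)Nc4ccccc4N)cc3)nc21` gives 71.9%; compound 3 `Nc1ccccc1NC(=O)c1ccc(COCNc2nc(Nc3cccc(Cl)c3)c3ncn(C4CCCC4)c3n2)cc1` gives 40.6%.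

Compound 3 is the lowest of the three, beyond the scatter in both comparisons. Compound 4 `Nc1ccccc1NC(=O)c1ccc(COCNc2nc(Nc3ccc(-c4ccccc4)cc3)c3ncn(C4CCCC4)c3n2)cc1` differs from it in one place: 4-phenylphenyl in place of 3-chlorophenyl on a nitrogen on an aromatic ring. For the measured compounds named here, one measured step bears on this: a number 36.3 percentage points lower from compound 1 to compound 3 (beyond the scatter), a large drop when the chlorine entered. Taking the chlorine away again should recover part of that, but no measured step shows what the added phenyl does, so the expected rise is moderate and uncertain: a number 14.4 percentage points higher from compound 3 to compound 4 (beyond the scatter). Compound 4 is therefore estimated at 55%, within a range from 25% to 85%.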

Compound 4, a percentage reported as inhibition, at one concentration (the size of the read-out at that concentration, not a potency): 25.8%
Estimate against measurement, compound 4: 29.2 percentage points above, within the range that was stated.
By their numbers in this assay, from the lowest: compound 4; then compound 3; then compounds 2 and 1 (each within the scatter of the next).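

Putting 4-phenylphenyl in place of 3-chlorophenyl on a nitrogen on an aromatic ring gives a number 14.8 percentage points lower from compound 3 to compound 4 (beyond the scatter), while furnishing the unsubstituted ring with a phenyl group gives a number 51.1 percentage points lower from compound 1 to compound 4 (beyond the scatter). So in this assay, both the chloro and the phenyl versions of this ring sit lower than the unsubstituted one, and the phenyl version sits lowest. Nothing shown gives a reason for these drops.

On these data alone, it remains open whether a smaller group on this ring, such as methoxy or an amine, would match compound 1.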